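A few compounds are considered here, and "the series" means these few. Any claim that something is new, unique, unknown or untested is made for them only; others in the source may bear on it.

In a functional assay on A-375 cells (Homo sapiens) for antiproliferative activity, read by MTT assay, with a stated time of 24 h (on this read-out higher numbers stand for weaker inhibition and lower numbers for stronger inhibition), compound 3 `COc1cc(OC)c(-c2coc3cc(OCc4ccc(Br)cc4)ccc3c2=O)cc1OC`, bearing a 4-bromobenzyl group, gives 1000 nM, within the scatter of compound 1 `COc1cc(OC)c(-c2coc3cc(OCC=C(C)C)ccc3c2=O)cc1OC`, which gives 1580 nM. Compound 2 `COc1cccc(C(=O)Oc2ccc3c(=O)c(-c4cc(OC)c(OC)cc4OC)coc3c2)c1` reads > 10000 nM, and that value is a limit. Compound 4 `COc1cc(OC)c(-c2coc3cc(OCc4ccc([N+](=O)[O-])cc4)ccc3c2=O)cc1OC` has nitro in place of bromo on an aromatic carbon, para to a large group (nitro in place of bromo on an aromatic carbon). For the measured compounds named here, no measured step makes this change. The closest evidence is a 1.6-fold lower number from compound 1 to compound 3 (0.20 log units; within the scatter), which stays within the scatter, while an at least 6.3-fold higher number from compound 1 to compound 2 (0.80 log units; beyond the scatter) and an at least 10-fold lower number from compound 2 to compound 3 (1.00 log units; beyond the scatter) both turn on the (3-methoxyphenyl)carbonyl group, which compound 4 lacks. No step beyond the scatter is therefore expected in this assay, and the estimated change is a 1.4-fold higher number from compound 3 to compound 4 (0.15 log units; within the scatter). For compound 4 the estimated value is 1400 nM, with an expected range from 500 nM to 4500 nM.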

Compound 4, half-maximal inhibitory concentration: > 10000 nM
Compound 4 was reported as a limit (the forecaster's own chance of this, stated with the estimate: 8%); middle value at least 7.1-fold (0.85 log units) away from the limit.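

Nitro in place of bromo on the aromatic carbon para to a large group is not a silent change in this assay: it gives an at least 10-fold higher number from compound 3 to compound 4 (1.00 log units; beyond the scatter), and the comparison with the other ether gives an at least 6.3-fold higher number from compound 1 to compound 4 (0.80 log units; beyond the scatter). The earlier 1.6-fold lower number from compound 1 to compound 3 (0.20 log units; within the scatter) had shown only that a 4-bromobenzyl group on this oxygen reads like the 3-methylbut-2-en-1-yl group, whereas here the group on that carbon decides the reading. Compound 4 stands at a limit, and its step from compound 2, also a limit, cannot be read: the limit of > 10000 nM in this assay, at which 2 of the 4 values shown sit.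

Only bromo and nitro are shown on this carbon, so it stays open how an amine, a methoxy group or a carboxylic acid there would read.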